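This account rests on a few compounds, and the source may have more. Where it says the series, first, only, none or still open, it means among the compounds named here.

In a functional assay on HepG2 cells (Homo sapiens) for antiproliferative activity, read by MTT assay, with a stated time of 48 h (a higher number here means a weaker inhibitor, a lower number a stronger inhibitor), compound 1 `O=C(Nc1cccc(CNc2nccnc2Cl)c1)Nc1ccc(Cl)cc1Br` gives 6720 nM, while compound 2 `O=C(Nc1cccc(CNc2nccnc2Cl)c1)NC1CCCC1` gives 18400 nM. For the measured compounds named here, compound 2 therefore holds the higher of the two numbers known so far, with compound 1 as its only neighbour; the single measured step between them, a 2.7-fold higher number from compound 1 to compound 2 (0.44 log units; beyond the scatter), came from cyclopentyl in place of 2-bromo-4-chlorophenyl on an amide-type nitrogen.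

Compound 3 `Cc1ccccc1NC(=O)Nc1cccc(CNc2nccnc2Cl)c1` differs from compound 2 at that same position: 2-methylphenyl in place of cyclopentyl on an amide-type nitrogen. Going by the values given here, the one measured step that bears on this change is a 2.7-fold higher number from compound 1 to compound 2 (0.44 log units; beyond the scatter), in which a six-membered aromatic ring of carbon only at the amide-type nitrogen was replaced by a five-membered non-aromatic ring and the number rose modestly. The step to compound 3 runs in the opposite sense, putting a six-membered aromatic ring of carbon only back at that nitrogen, so the number is expected to fall by a comparable margin, a 2.3-fold lower number from compound 2 to compound 3 (0.36 log units; beyond the scatter). Among the compounds with values here, since only one such step is known, the uncertainty is wide. The estimate for compound 3 in this assay is 8000 nM, expected to lie between 3500 nM and 18000 nM.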

Compound 3, half-maximal inhibitory concentration: 15300 nM
Beside the measured number, compound 3's estimate is 1.9-fold (0.28 log units) below it; the range from low to high includes it.
By their numbers in this assay, from the lowest: compound 1; then compounds 3 and 2 (each within the scatter of the next).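

In this assay, a six-membered aromatic ring of carbon only at the amide-type nitrogen does not by itself set a compound apart from one with cyclopentyl there: 2-methylphenyl in place of cyclopentyl gives a 1.2-fold lower number from compound 2 to compound 3 (0.08 log units; within the scatter), so compound 2 and compound 3 cannot be told apart in this assay. With such a ring kept at that nitrogen and only its substituents changed, 2-methylphenyl in place of 2-bromo-4-chlorophenyl gives a 2.3-fold higher number from compound 1 to compound 3 (0.36 log units; beyond the scatter), so among these three compounds the gap beyond the scatter belongs to the 2-bromo-4-chlorophenyl group in particular, and not to aromatic rings at this position in general. Nothing at hand offers an explanation for this difference between the two substituted rings.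

Going by these compounds, it remains open whether the bromo or the chloro substituent of compound 1 carries the step, and how plain phenyl, or a ring bearing an amine or a carboxylic acid, would read at this nitrogen. All three compounds share the same core, so they also say nothing about changes made elsewhere in the structure.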